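Replacing the Bromine of Compound 3

The compounds below may be only part of what the source reports. "The series", "measured", "known", "first", "only" and "open" are said of these compounds alone.

In a functional assay on HeLa cells (Homo sapiens) for antiproliferative activity, read by MTT assay, with a stated time of 48 h (a higher number here means a weaker inhibitor, a lower number a stronger inhibitor), compound 1 `COc1ccc(N(C)c2ccnc(Cl)n2)cc1` gives 917 nM. Compound 2 `COc1ccc(N(C)c2ccnc(Cl)n2)cc1F`, with fluoro in place of hydrogen on an aromatic carbon, gives 241 nM, which is a 3.8-fold lower number from compound 1 to compound 2 (0.58 log units; beyond the scatter). Compound 3 `COc1ccc(N(C)c2ccnc(Cl)n2)cc1OCCCCBr`, with 4-bromobutoxy in place of hydrogen on an aromatic carbon, gives 307 nM. That is a 3.0-fold lower number from compound 1 to compound 3 (0.48 log units; beyond the scatter), while the comparison with the fluoro analogue is a 1.3-fold higher number from compound 2 to compound 3 (0.11 log units; within the scatter). Compound 3 therefore stands clear of compound 1 but cannot be separated from compound 2.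

Compound 4 `COc1ccc(N(C)c2ccnc(Cl)n2)cc1OCCCC[Se]C#N` differs from compound 3 at a single place: a group of 3 heavy atoms (1 carbon, 1 nitrogen, 1 selenium; no ring) in place of one bromine atom, on a saturated chain carbon, four bonds along the chain from an oxygen on an aromatic ring. The change lies on a saturated chain carbon, four bonds along the chain from an oxygen on an aromatic ring. Going by the values given here, no measured step alters that carbon, so the evidence is indirect. The closest guide is the step that introduced the chain, a 3.0-fold lower number from compound 1 to compound 3 (0.48 log units; beyond the scatter), and it was modest. A modest step in the same direction is therefore expected, a 2.2-fold lower number from compound 3 to compound 4 (0.34 log units; beyond the scatter), although this expectation is weakly grounded. For compound 4 the estimated value is 140 nM, with an expected range from 40 nM to 450 nM.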

Compound 4, half-maximal inhibitory concentration: > 10000 nM
Compound 4 was reported as a limit; the forecaster's own chance of this, stated with the estimate: 2%; middle value at least 71-fold (1.85 log units) from the limit.
By their numbers in this assay, from the lowest: compounds 2 and 3 (each within the scatter of the next); then compound 1. At a limit, above all of these: compound 4.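

Going by these compounds alone, at the end of the chain, which no earlier compound had altered, the replacement of bromo by the group of carbon, nitrogen and selenium has a large effect in this assay, with an at least 32-fold higher number from compound 3 to compound 4 (1.51 log units; beyond the scatter). Within the data shown here, the change also cancels the benefit seen with the chain, since the comparisons with the earlier compounds give an at least 10-fold higher number from compound 1 to compound 4 (1.03 log units; beyond the scatter) and an at least 41-fold higher number from compound 2 to compound 4 (1.61 log units; beyond the scatter), so the chain does not carry activity whatever stands at its end. The value for compound 4 is a limit and not a number: the limit of > 10000 nM in this assay, at which 1 of the 4 values shown sits.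

The compounds shown leave open whether the loss follows the selenium or the nitrile, which a sulfur atom in place of the selenium, or a nitrile set directly on the chain, could help separate. They also leave open whether the chain end accepts other groups in place of bromine, such as an amine or a hydroxyl, and whether a shorter or longer chain carrying the same group behaves in the same way.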